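Working notes: 4-methoxyphenyl to phenyl in the series

The source may report more compounds than this note shows. Statements on the series, on what has been measured and on what is new or still open speak of the compounds shown alone.

The series is tested in a functional assay on HCT-15 cells (Homo sapiens) for inhibition, read by sulforhodamine B assay, with a stated time of 48 h; a lower number here means a stronger inhibitor of growth, a higher number a weaker inhibitor of growth. Compound 1 `COc1ccc(-c2[nH]c3ccccc3c2/C=C(\C#N)S(=O)(=O)c2ccccc2)cc1` gives 554 nM. Compound 2 `COc1ccc(-c2[nH]c3ccc(OC)cc3c2/C=C(\C#N)S(=O)(=O)c2ccccc2)cc1` gives 632 nM; of the two numbers compound 2 carries the higher one, its nearest neighbour being compound 1, yet the step of a 1.1-fold higher number from compound 1 to compound 2 (0.06 log units; within the scatter) lies within the scatter, so the two are not distinguished. Compound 3 `COc1ccc2[nH]c(-c3ccccc3)c(/C=C(\C#N)S(=O)(=O)c3ccccc3)c2c1` is not yet measured. It differs from compound 2 by hydrogen in place of methoxy on an aromatic carbon, which read one bond further out is 4-methoxyphenyl to phenyl. Among the compounds with values here, only one measured step exists, and it concerns a methoxy at a different place, so it bears on the present change only loosely; it showed nothing beyond the scatter. Compound 3 is therefore expected to show a 1.1-fold lower number from compound 2 to compound 3 (0.02 log units; within the scatter), a step of no size beyond the scatter and of no firm direction. The estimate for compound 3 is 600 nM, in the range 300 nM to 1200 nM.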

Compound 3, concentration for 50% growth inhibition: 4000 nM
Compound 3: middle estimate off by 6.7-fold (0.82 log units), on the low side; the whole stated range lies below it.
By their numbers in this assay, from the lowest: compounds 1 and 2 (each within the scatter of the next); then compound 3.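

Within the data shown here, the change from 4-methoxyphenyl to phenyl gives the first step in this assay that lies beyond the scatter (a 6.3-fold higher number from compound 2 to compound 3 (0.80 log units; beyond the scatter)), so this position matters for growth inhibition in a way the earlier pair could not show. The methoxy elsewhere on the core gave only a 1.1-fold higher number from compound 1 to compound 2 (0.06 log units; within the scatter), so the result for one methoxy does not carry over to the other. No measurement at hand accounts for the size of this step.

From the compounds shown here alone, whether the gain belongs to methoxy itself or would also come with another group at this place remains open; a hydroxy, an ethoxy, a fluorine or a dimethylamino group would separate these readings. Among these compounds, also open is whether the step keeps its size on the core without the second methoxy, as only this one pair bears on it.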